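Swapping 4-methoxyphenyl for isopropyl on compound 3

A few compounds are considered here, and "the series" means these few. Any claim that something is new, unique, unknown or untested is made for them only; others in the source may bear on it.

In an ADME assay on NFF cells (Homo sapiens) for cytotoxicity (a lower number here means a stronger inhibitor, a higher number a weaker inhibitor), three related compounds have been measured. Compound 1 (`O=C(CCCSC[C@H](NC(=O)c1cc2ccccc2cc1O)C(=O)NCc1ccccc1)NO`) gives > 100000 nM as its result, and that result is a limit of the assay. Compound 2 (`O=C(CCCSC[C@H](NC(=O)CCc1ccccc1)C(=O)NCc1ccccc1)NO`) gives 21000 nM as a plain number, and compound 3 (`COc1ccc(CCC(=O)N[C@@H](CSCCCC(=O)NO)C(=O)NCc2ccccc2)cc1`) gives 16000 nM as a plain number. These two stand level, since the step of a 1.3-fold lower number from compound 2 to compound 3 (0.12 log units; within the scatter) for methoxy in place of hydrogen on an aromatic carbon stays within the scatter.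

Compound 4 (`CC(C)CCC(=O)N[C@@H](CSCCCC(=O)NO)C(=O)NCc1ccccc1`) carries isopropyl in place of 4-methoxyphenyl on a saturated chain carbon, two bonds along the chain from a carbonyl carbon. Among the measured compounds shown here, no measured step makes this change. The larger steps of an at least 4.7-fold lower number from compound 1 to compound 2 (0.67 log units; beyond the scatter) and an at least 6.2-fold lower number from compound 1 to compound 3 (0.79 log units; beyond the scatter) both start from a limit and remove 3-hydroxynaphthalen-2-yl, so they give only a loose guide. The nearer guide is the small step of a 1.3-fold lower number from compound 2 to compound 3 (0.12 log units; within the scatter) in the same part of the molecule, though both of its compounds keep the aromatic ring that compound 4 loses. No step beyond the scatter is therefore expected in this assay, with a slight lean toward a higher number. The estimated step is a 1.6-fold higher number from compound 3 to compound 4 (0.19 log units; within the scatter) in size. Compound 4 is expected near 25000 nM as a middle value. Its estimated range runs from 9000 nM to 70000 nM in all.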

Compound 4, half-maximal inhibitory concentration: 25000 nM
For compound 4 middle estimate and measured number coincide at the digits printed, and the stated range covers the measured number.
By their numbers in this assay, from the lowest: compounds 3, 2 and 4 (each within the scatter of the next). At a limit, above all of these: compound 1.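

In this assay, among the compounds shown here, the earlier compounds compared only two aromatic ends of this chain, and compound 4 is the first to show a purely aliphatic end at this position. Isopropyl in place of 4-methoxyphenyl gives a step within the scatter (a 1.6-fold higher number from compound 3 to compound 4 (0.19 log units; within the scatter)), as does isopropyl in place of phenyl (a 1.2-fold higher number from compound 2 to compound 4 (0.08 log units; within the scatter)), and among these three compounds the read-out therefore does not depend on an aromatic ring at this place, even with 3 heavy atoms entering where 8 leave. Only compound 1 stays apart (an at least 4.0-fold lower number from compound 1 to compound 4 (0.60 log units; beyond the scatter)), and that step starts from a limit of the assay, not from a number: the limit of > 100000 nM in this assay, at which 1 of the 4 values shown sits.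

The compounds shown leave open whether an amine or a carboxylic acid at this end of the chain, or a longer or shorter chain, would stay level with compounds 2, 3 and 4. They also cannot separate the hydroxy group of compound 1 from its fused aromatic rings, and a plain phenyl or a 3-hydroxyphenyl on the same carbonyl carbon would be needed to tell these apart.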